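From phenyl to cyclopentylmethyl: a step from compound 1

A few compounds are considered here, and "the series" means these few. Any claim that something is new, unique, unknown or untested is made for them only; others in the source may bear on it.

Compound 1, `CNc1nc(-n2cc(-c3ccccc3)nn2)nc2c1ncn2[C@@H]1O[C@H](CO)[C@@H](O)[C@H]1O`: 14.9 nM in an assay on CHO cells for displacement of a labelled ligand from adenosine receptor A3 (Homo sapiens); a higher number here means a weaker inhibitor, a lower number a stronger inhibitor
Compound 2, `CCNC(=O)[C@H]1O[C@@H](n2cnc3c(NC)nc(-n4cc(Cc5ccccc5)nn4)nc32)[C@H](O)[C@@H]1O`: 2.8 nM in this assay
Compound 3, `CCc1cn(-c2nc(NC)c3ncn([C@@H]4O[C@H](CO)[C@@H](O)[C@H]4O)c3n2)nn1`: 13.8 nM in this assay

Among these three numbers compound 1 stands highest. Its closest neighbour is compound 3, with the change a 1.1-fold lower number from compound 1 to compound 3 (0.03 log units; within the scatter), so the two are not distinguishable. Compound 2 gives a lower number than compound 1, but it differs from compound 1 in two places at once, so its value alone says nothing about the group on the aromatic carbon of the five-membered ring.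

The step under consideration leads to compound 4, `CNc1nc(-n2cc(CC3CCCC3)nn2)nc2c1ncn2[C@@H]1O[C@H](CO)[C@@H](O)[C@H]1O`. The change is cyclopentylmethyl in place of phenyl on an aromatic carbon. Going by the values given here, only one measured step touches the same position: the exchange of phenyl for ethyl, a 1.1-fold lower number from compound 1 to compound 3 (0.03 log units; within the scatter), which left the number where it was. A saturated carbon group in place of phenyl has therefore, so far, made no difference beyond the scatter, and cyclopentylmethyl is expected to behave in the same way, with no clear step in this assay in either direction.

On that basis compound 4 is estimated at 12 nM, with a range from 4 nM to 40 nM, which corresponds to an expected change of a 1.2-fold lower number from compound 1 to compound 4 (0.09 log units; within the scatter).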

Compound 4, inhibition constant: 1.3 nM
Compound 4: the middle estimate sits 9.2-fold (0.97 log units) above what was measured; measured number outside the range, below it.
By their numbers in this assay, from the lowest: compound 4; then compound 2; then compounds 3 and 1 (each within the scatter of the next).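

The group on the aromatic carbon of the five-membered ring is not indifferent in this assay: cyclopentylmethyl in place of phenyl gives an 11-fold lower number from compound 1 to compound 4 (1.06 log units; beyond the scatter), whereas ethyl in place of phenyl stayed within the scatter, so replacing phenyl with a saturated carbon group does not by itself fix the number. Against the ethyl compound the step is of the same size, an 11-fold lower number from compound 3 to compound 4 (1.03 log units; beyond the scatter), and as phenyl and cyclopentylmethyl have the same count of heavy atoms and neither has hydrogen-bond donors or acceptors, those counts do not separate compound 1 from compound 4; what the computed comparison does set apart is a six-membered aromatic ring against a five-membered non-aromatic ring. Nothing at hand bears on the reason for these steps.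

The compounds shown leave open whether the step belongs to the cyclopentyl ring or to the chain carbon that carries it, which cyclopentyl attached directly to the aromatic carbon, or cyclohexylmethyl, would help to separate. They also leave open whether a longer open chain such as pentyl would match cyclopentylmethyl at this position.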